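This account rests on a few compounds, and the source may have more. Where it says the series, first, only, none or still open, it means among the compounds named here.

Measured in a functional assay on A2780cisR cells (Homo sapiens) for antiproliferative activity, read by MTT assay, with a stated time of 72 h; on this read-out lower numbers stand for stronger inhibition and higher numbers for weaker inhibition:
- compound 1 `O=C(CCCCCONC(=O)Nc1cccc2ccccc12)NO`: 7900 nM
- compound 2 `COc1cc(NC(=O)NOCCCCCC(=O)NO)c2nc(OC)cc(C)c2c1`: 400 nM

Of these two, compound 1 has the higher number, 7900 nM, and so shows the weaker inhibition. The gap to compound 2 lies beyond the scatter.

Compound 3 `CN(O)C(=O)CCCCCONC(=O)Nc1cccc2ccccc12` is compound 1 with a single change: methyl in place of hydrogen on an amide-type nitrogen. Within the data shown here, no measured pair shows this change, so the expectation is a judgement from the structures alone. A step towards weaker inhibition, beyond the scatter, is expected in this assay, an estimated 5.1-fold higher number from compound 1 to compound 3 (0.70 log units; beyond the scatter). For compound 3 the estimated value is 40000 nM, with an expected range of 14000 nM to 100000 nM.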

Compound 3, half-maximal inhibitory concentration: 44200 nM
Beside the measured number, compound 3's estimate is 1.1-fold (0.04 log units) below it; the range from low to high includes it.
By their numbers in this assay, from the lowest: compound 2; then compound 1; then compound 3.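

In this assay, methyl in place of hydrogen on the amide-type nitrogen that also carries the carbonyl carbon and oxygen gives a 5.6-fold higher number from compound 1 to compound 3 (0.75 log units; beyond the scatter). Among these compounds, this is the first direct sign that inhibition responds to this one position, as the earlier pair differs elsewhere. Nothing shown gives a reason for this loss.

Still open, going by these compounds, is how ethyl on this nitrogen, or a carboxylic acid in place of hydroxycarbamoyl, would compare. Also open, on these data alone, is whether the same methyl would weaken compound 2 to a similar degree.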